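This account rests on a few compounds, and the source may have more. Where it says the series, first, only, none or still open, it means among the compounds named here.

Compound 1 `Oc1cccc(-c2cc(-c3ccccc3F)cc(-c3ccccc3O)n2)c1` carries three aryl groups on a shared core, two of them bearing hydroxyl groups and one a fluoro group. In a functional assay on HeLa cells (Homo sapiens) for inhibition (on this read-out lower numbers stand for stronger inhibition and higher numbers for weaker inhibition), compound 1 gives 31100 nM. Compound 2 `Oc1cccc(-c2cc(-c3ccccc3F)cc(-c3cccc(O)c3)n2)c1`, which moves one hydroxyl, gives 16000 nM in this assay, and compound 3 `Oc1cccc(-c2cc(-c3cccc(C(F)(F)F)c3)cc(-c3ccccc3O)n2)c1`, which swaps the fluoro-bearing ring for one carrying trifluoromethyl, gives 19500 nM. Compound 1 thus shows the largest of the three numbers, but neither neighbour is separated from it by more than the usual scatter: the step is a 1.9-fold lower number from compound 1 to compound 2 (0.29 log units; within the scatter) and a 1.6-fold lower number from compound 1 to compound 3 (0.20 log units; within the scatter).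

Compound 4 `Oc1cccc(-c2cc(-c3ccccc3OC(F)(F)F)cc(-c3ccccc3O)n2)c1` differs from compound 1 in one place: trifluoromethoxy in place of fluoro on an aromatic carbon. Going by the values given here, the step that bears most on this change is the one from compound 1 to compound 3, where a fluoro group was also replaced by a fluorine-rich group on the same ring; that step stayed within the scatter. Among the compounds with values here, the only other step available, from compound 1 to compound 2, was likewise within the scatter. On this narrow basis no step beyond the scatter is expected in this assay, in either direction, so the estimated step is a 1.2-fold lower number from compound 1 to compound 4 (0.09 log units; within the scatter). The expected value for compound 4 is therefore 25000 nM, with a likely range from 8000 nM to 70000 nM.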

Compound 4, half-maximal inhibitory concentration: 15200 nM
Compound 4: middle estimate off by 1.6-fold (0.22 log units), on the high side; the range from low to high includes it.
By their numbers in this assay, from the lowest: compounds 4, 2, 3 and 1 (each within the scatter of the next, the first and the last beyond it).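

In this assay, putting trifluoromethoxy in place of fluoro on this aromatic carbon, ortho to a large group, gives a 2.0-fold lower number from compound 1 to compound 4 (0.31 log units; beyond the scatter), a modest change but the only step shown that lies beyond the scatter. The earlier steps shown here could not show any clear change from compound 1, whereas this one shows that the number can fall at this position. It also shows that the position accepts a group of 5 heavy atoms in place of one of 1 heavy atom without any rise in the number, so a larger group here does not cost inhibition in this series. No measurement is available that explains why this change lowers the number.

The compounds shown leave open how other groups on this same carbon would behave, such as methoxy, which lacks the three fluorines, or an amine or a carboxylic acid. Also open, going by these compounds, is whether trifluoromethoxy would give a similar step when paired with the 3-hydroxyphenyl group of compound 2, rather than the 2-hydroxyphenyl group of compound 1.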